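From phenyl to pyridin-4-yl on compound 2

This account rests on a few compounds, and the source may have more. Where it says the series, first, only, none or still open, it means among the compounds named here.

In an in vitro ADME assay on microsomes from liver (Homo sapiens) for metabolic stability (on this read-out lower numbers stand for slow clearance and higher numbers for fast clearance), compound 2 (`O=C(COCc1ccccc1)N1CCN(c2ccc(F)cc2F)CC1`) gives 580 mL.min-1.g-1 as the highest of three numbers, against compound 1 (`O=C(COCc1ccccc1)N1CCN(c2ccc(F)cc2)CC1`) at 110 mL.min-1.g-1 and compound 3 (`O=C(COCc1ccccc1)N1CCN(c2cc(Cl)ccn2)CC1`) at 130 mL.min-1.g-1 in the same series. Compound 4 (`O=C(COCc1ccncc1)N1CCN(c2ccc(F)cc2F)CC1`) carries pyridin-4-yl in place of phenyl on a saturated chain carbon bound to an oxygen on a saturated carbon, turning benzyloxy into (pyridin-4-yl)methoxy. Among the measured compounds shown here, no measured step touches that place, so the evidence is indirect. All three steps alter the group on the amine nitrogen in a ring. Fluoro in place of hydrogen came with a 5.3-fold higher number from compound 1 to compound 2 (0.72 log units; beyond the scatter) and 4-chloropyridin-2-yl in place of 2,4-difluorophenyl came with a 4.5-fold lower number from compound 2 to compound 3 (0.65 log units; beyond the scatter) as a modest drop. Yet 4-chloropyridin-2-yl in place of 4-fluorophenyl came with only a 1.2-fold higher number from compound 1 to compound 3 (0.07 log units; within the scatter) as a caution. For the measured compounds named here, a smaller drop than the one to compound 3 therefore seems reasonable. The expected step is a 2.4-fold lower number from compound 2 to compound 4 (0.38 log units; beyond the scatter) in this assay and it remains an uncertain estimate. For compound 4 the estimated value is 240 mL.min-1.g-1 with an expected range from 100 mL.min-1.g-1 to 560 mL.min-1.g-1 in this measurement.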

Compound 4, intrinsic clearance in microsomes: 22 mL.min-1.g-1
Compound 4: middle estimate off by 11-fold (1.04 log units), on the high side; measured number outside the range, below it.
By their numbers in this assay, from the lowest: compound 4; then compounds 1 and 3 (each within the scatter of the next); then compound 2.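

In this assay, among the compounds shown here, pyridin-4-yl in place of phenyl gave a 26-fold lower number from compound 2 to compound 4 (1.42 log units; beyond the scatter) and so shows that the place on a saturated chain carbon bound to an oxygen on a saturated carbon, which no earlier step touched, strongly moves this read-out; the step is larger than the one seen on the amine nitrogen, a 5.3-fold higher number from compound 1 to compound 2 (0.72 log units; beyond the scatter). The change is small in atoms, since both groups hold 6 heavy atoms and pyridin-4-yl brings 1 nitrogen and 1 hydrogen-bond acceptor with no net charge. No measurement in hand accounts for the size of this step.

As far as these compounds go, whether a pyridin-3-yl or a pyrimidin-5-yl group at this place would give a similar step remains open. So does whether pyridin-4-yl would act alike with the 4-fluorophenyl of compound 1 or the 4-chloropyridin-2-yl of compound 3.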